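This account rests on a few compounds, and the source may have more. Where it says the series, first, only, none or still open, it means among the compounds named here.

The measured compounds:
compound 1, `COc1cc(NC(C)CCCNC(=O)NNC(=O)/C=C/c2ccccc2)c2ncccc2c1`, gives 13900 nM in an ADME assay on L6 cells (Rattus norvegicus) for cytotoxicity, read by resazurin assay, with a stated time of 70 h; on this read-out higher numbers stand for weaker inhibition and lower numbers for stronger inhibition;
compound 2, `COc1cc(NC(C)CCCNC(=O)NNC(=O)/C=C/c2ccc(OC)c(OC)c2)c2ncccc2c1`, gives 37000 nM;
compound 3, `COc1cc(NC(C)CCCNC(=O)NNC(=O)NCCCCCO)c2ncccc2c1`, gives "not determined" (no result reported), that is, no result reported.

Compound 3 therefore stands nowhere on the numbers shown: it carries no value in this assay, and nothing can be said of how it compares with compound 1 or compound 2. Within the data shown here, the only measured step is a 2.7-fold higher number from compound 1 to compound 2 (0.43 log units; beyond the scatter), which alters the group on the double-bonded chain carbon. That part of the molecule is absent from compound 3 and compound 4, so this step does not bear on the change considered here; it only shows the range in which two compounds with the shared core fall.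

Compound 4, `COc1cc(NC(C)CCCNC(=O)NNC(=O)Nc2cccc(C(F)(F)F)c2)c2ncccc2c1`, differs from compound 3 by 3-(trifluoromethyl)phenyl in place of 5-hydroxypentyl on an amide-type nitrogen. Compound 3 has no number. No step size can be projected for this change, and no direction beyond the scatter can be claimed. What remains is the position of compound 1 and compound 2, which share the core with compound 4 and whose values set the expected region. On that basis compound 4 is estimated to give about 20000 nM, with a range of 6000 nM to 70000 nM.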

Compound 4, half-maximal inhibitory concentration: 32100 nM
Compound 4: middle estimate off by 1.6-fold (0.21 log units), on the low side, within the range that was stated.
By their numbers in this assay, from the lowest: compound 1; then compounds 4 and 2 (each within the scatter of the next).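

In this assay, among these compounds, putting (3-(trifluoromethyl)phenyl)amino on the carbonyl carbon in place of 2-(3,4-dimethoxyphenyl)ethenyl gives a 1.2-fold lower number from compound 2 to compound 4 (0.06 log units; within the scatter) and so shows no change that can be read, which is the first sign that this position can carry an arylamino group instead of a substituted ethenyl group without leaving the level of compound 2. Set against 2-phenylethenyl, the same group gives a 2.3-fold higher number from compound 1 to compound 4 (0.36 log units; beyond the scatter) and thus a modest step, so the reading depends on which of the two ethenyl compounds serves as the reference, and compound 4 sits with compound 2 rather than with compound 1. Nothing among the data accounts for either step.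

The steps from compound 3 cannot be read, so the exchange of 5-hydroxypentyl for 3-(trifluoromethyl)phenyl on the amide-type nitrogen still has no size or direction. Among the compounds shown here, it also remains open whether the trifluoromethyl group itself matters on this phenyl ring, since no compound here carries a nitrile, a carboxylic acid or a plain hydrogen in its place.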